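A few compounds are considered here, and "the series" means these few. Any claim that something is new, unique, unknown or untested is made for them only; others in the source may bear on it.

Three compounds sharing one core differ in the aryl group on an amide-type nitrogen. In a functional assay on A549 cells (Homo sapiens) for inhibition, read by CCK-8 assay, with a stated time of 72 h, tested at 1 uM (on this read-out higher numbers stand for more inhibition of growth at the one concentration tested and lower numbers for less inhibition of growth), compound 1 `COC(=O)c1ccc(NC(=O)C2(C(=O)Nc3ccc(Nc4ncc5cc(C(=O)N(C)C)n(C6CCCC6)c5n4)cc3)CC2)cc1` gives 77.1%, compound 2 `CN(C)C(=O)c1cc2cnc(Nc3ccc(NC(=O)C4(C(=O)Nc5cccc(F)c5)CC4)cc3)nc2n1C1CCCC1` gives 33.2% and compound 3 `CN(C)C(=O)c1cc2cnc(Nc3ccc(NC(=O)C4(C(=O)Nc5cccc(Cl)c5)CC4)cc3)nc2n1C1CCCC1` gives 8.3%. Compound 3 is thus the lowest of the three, and its gaps to both others lie beyond the scatter. Compound 4 `COc1cccc(NC(=O)C2(C(=O)Nc3ccc(Nc4ncc5cc(C(=O)N(C)C)n(C6CCCC6)c5n4)cc3)CC2)c1` carries methoxy in place of chloro on an aromatic carbon, meta to a large group: methoxy in place of chloro on an aromatic carbon. Among the compounds with values here, no measured step makes this exchange. The closest is a number 24.9 percentage points lower from compound 2 to compound 3 (beyond the scatter), a swap of chloro for fluoro. The wider steps, a number 43.9 percentage points lower from compound 1 to compound 2 (beyond the scatter) and a number 68.8 percentage points lower from compound 1 to compound 3 (beyond the scatter), show how far a change of this aryl group can move the read-out, though both also change the group's place and kind. With compound 3 at 8.3%, there is little room to fall, so a modest upward step is expected, with wide uncertainty. The estimated move is a number 19.7 percentage points higher from compound 3 to compound 4 (beyond the scatter). For compound 4 the expected value is 28%, with an estimated range of 8% to 58%.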

Compound 4, percent growth inhibition at one concentration: 77.2%
Compound 4: middle estimate off by 49.2 percentage points, on the low side; the measured number lies above the stated range.
By their numbers in this assay, from the lowest: compound 3; then compound 2; then compounds 1 and 4 (each within the scatter of the next).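

Methoxy in place of chloro, meta to a large group, gives a number 68.9 percentage points higher from compound 3 to compound 4 (beyond the scatter) in this assay and methoxy in place of fluoro gives a number 44 percentage points higher from compound 2 to compound 4 (beyond the scatter) at the same place, so the read-out here depends far more on the group than the modest halogen exchange had shown. The 3-methoxyphenyl group, set against the 4-(methoxycarbonyl)phenyl group, shows a number 0.1 percentage points higher from compound 1 to compound 4 (within the scatter) and thus matches a read-out that neither halogen-bearing ring reached. No measured property of these groups is at hand to account for these steps.

The compounds shown leave open whether hydroxy, ethoxy or dimethylamino at this place would hold the read-out or lose it. As far as these compounds go, whether compound 1 and compound 4 would also stay together at other concentrations remains open too.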